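From 2-carbamoylphenyl to 1,3-benzothiazol-2-yl on the amide

The source may hold more compounds than are shown below. What is called first, only, known or untested is meant among the compounds shown, and "the series" means these compounds.

In an ADME assay on MDCK cells (Canis lupus familiaris) for cytotoxicity, read by MTT assay, with a stated time of 48 h (on this read-out higher numbers stand for lower toxicity in this test and lower numbers for higher toxicity in this test), compound 3 (`Cc1cc(-c2ccccc2)nc2nc(C(=O)Nc3ccccc3C(N)=O)nn12`) stands at > 250000 nM as a limit and not a number. Compound 1 (`Cc1cc(-c2ccccc2)n2nc(C(=O)Nc3sc4c(c3C(N)=O)CCC4)nc2n1`) also reads > 250000 nM as a limit. Compound 2 (`Cc1cc(-c2ccccc2)nc2nc(C(=O)Nc3ccsc3C(N)=O)nn12`) gives a true number of 240000 nM in this assay at the top of the range. The series thus sits at the limit of > 250000 nM in this assay, at which 2 of the 3 values shown sit, and offers little resolution. Compound 4 (`Cc1cc(-c2ccccc2)nc2nc(C(=O)Nc3nc4ccccc4s3)nn12`) carries 1,3-benzothiazol-2-yl in place of 2-carbamoylphenyl on an amide-type nitrogen. Within the data shown here, the one measured step at this nitrogen, an at least 1.0-fold higher number from compound 2 to compound 3 (0.01 log units; that floor lies within the scatter), is small, so no change beyond the scatter is expected in this assay here. The expected step is an at least 1.1-fold lower number from compound 3 to compound 4 (0.05 log units; that floor lies within the scatter) in size. Compound 4 is estimated at 220000 nM with an expected range of 100000 nM to 350000 nM for repeat readings.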

Compound 4, half-maximal cytotoxic concentration: 233000 nM
For compound 4 the middle estimate is 1.1-fold (0.02 log units) below the measured one, within the range that was stated.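

Replacing the carbamoyl-bearing aryl group on the amide-type nitrogen with 1,3-benzothiazol-2-yl, which has 0 hydrogen-bond donors, leaves the read-out in this assay within the scatter on both steps (an at least 1.0-fold lower number from compound 3 to compound 4 (0.03 log units; that floor lies within the scatter)) and (a 1.0-fold lower number from compound 2 to compound 4 (0.01 log units; within the scatter)). The carbamoyl group is therefore not required for this flat cytotoxicity reading at this position. Resolution at the top of the range remains poor: the limit of > 250000 nM in this assay, at which 2 of the 4 values shown sit.

Still open, from the compounds shown here alone, is how an amine or a carboxylic acid on the aryl group at this position would read. A longer alkyl chain on this nitrogen is equally unresolved.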